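The source may hold more compounds than are shown below. What is called first, only, known or untested is meant among the compounds shown, and "the series" means these compounds.

The account concerns two measured compounds and one that awaits measurement in an ADME assay on L02 cells (Homo sapiens) for inhibition, read by CCK-8 assay, with a stated time of 48 h; a higher number here means a weaker inhibitor of growth, a lower number a stronger inhibitor of growth. Compound 1, `Cc1ccccc1Nc1nc(Nc2ccc(N3CCCN(C)CC3)cc2)ncc1Cl`, gives 1240 nM. Compound 2, `COc1cccc(CNc2nc(Nc3ccc(N4CCN(C)CC4)cn3)ncc2Cl)c1`, gives 16200 nM, the highest of the two numbers recorded; against compound 1 it stands at a higher number, a gap beyond the usual scatter, so compound 2 is the weaker inhibitor of growth of the pair.

Compound 3, `CN1CCN(c2ccc(Nc3ncc(Cl)c(Nc4ccc(C(C)(C)C)cc4)n3)nc2)CC1`, is the compound to be measured next. It arises from compound 2 by a single change: 4-(tert-butyl)phenyl in place of 3-methoxybenzyl on a nitrogen on an aromatic ring.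

For the measured compounds named here, no step between measured compounds that differ in one place is available, so the size of this change in this assay cannot be read from a measured precedent. Because compound 2 sits at 16200 nM while compound 1 sits at 1240 nM, the expectation for compound 3 is a move toward compound 1, that is, a lower number, of moderate size and beyond the scatter, expressed as a 3.6-fold lower number from compound 2 to compound 3 (0.56 log units; beyond the scatter). On that basis compound 3 is estimated at 4500 nM, with a range from 1500 nM to 13000 nM.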

Compound 3, concentration for 50% growth inhibition: 6070 nM
Beside the measured number, compound 3's estimate is 1.3-fold (0.13 log units) below it, and the stated range covers the measured number.
By their numbers in this assay, from the lowest: compound 1; then compound 3; then compound 2.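

In this assay the position on a nitrogen on an aromatic ring now has its first measured step, a 2.7-fold lower number from compound 2 to compound 3 (0.43 log units; beyond the scatter), which shows that this site responds to a change of group, modestly but beyond the scatter, in the direction of stronger inhibition of growth. The change takes out 3-methoxybenzyl, with its hydrogen-bond acceptor, and puts in the all-carbon 4-(tert-butyl)phenyl, so a group without an acceptor is tolerated here with no loss of inhibition, although a single step cannot divide the shift among the parts of a group exchanged whole. Nothing in the data given bears on why the number moves.

The compounds shown leave open how far the shift belongs to the tert-butyl group itself, which unsubstituted phenyl or 4-methoxyphenyl on the same nitrogen could separate from the rest of the exchange. They also leave open whether a group of another kind at this place, such as a carboxylic acid or an amine carried on the aromatic ring, would move the number further or return it.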